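The source may hold more compounds than are shown below. What is called first, only, known or untested is meant among the compounds shown, and "the series" means these compounds.

Measured so far in an assay on cells for binding affinity to Neuropeptide Y receptor type 1 (Homo sapiens); a higher number here means a weaker inhibitor, a lower number a stronger inhibitor:
- compound 1 `CCCCCCCOc1cc(CCc2nc(C)c(CC)s2)nc(NCc2cc(Cl)cc(NC(=O)OC(C)C)c2)c1`: 72 nM
- compound 2 `CCc1sc(CCc2cc(OCC(C)(C)C)cc(NCc3cc(Cl)cc(NC(=O)OC(C)C)c3)n2)nc1C`: 55 nM
- compound 3 `CCc1sc(CCc2cc(OC(CC)CC)cc(NCc3cc(Cl)cc(NC(=O)OC(C)C)c3)n2)nc1C`: 5.5 nM

Compound 3 stands lowest of the three in this assay; the others differ only in the group on the aromatic oxygen. Compound 1 to compound 2 changed hexyl to tert-butyl on the chain carbon bound to that oxygen, giving a 1.3-fold lower number from compound 1 to compound 2 (0.12 log units; within the scatter). The move to pentan-3-yl was large in both comparisons: a 13-fold lower number from compound 1 to compound 3 (1.12 log units; beyond the scatter) and a 10-fold lower number from compound 2 to compound 3 (1.00 log units; beyond the scatter).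

Compound 4 `CCc1sc(CCc2cc(OC3CCOCC3)cc(NCc3cc(Cl)cc(NC(=O)OC(C)C)c3)n2)nc1C` brings oxan-4-yl in place of pentan-3-yl on an oxygen on an aromatic ring: a group with one six-membered non-aromatic ring with 1 hetero atom and 1 hydrogen-bond acceptor replaces an open chain. As far as these compounds go, only the two steps into compound 3 bear on this place, and both concern chain shape; none introduces a ring or an acceptor there, so the effect of the oxygen is unknown. Since the attachment carbon stays branched as in compound 3, a small to modest change is expected, with a weakening somewhat more likely: a 2.2-fold higher number from compound 3 to compound 4 (0.34 log units; beyond the scatter). Compound 4 is estimated at 12 nM, range 4 nM to 40 nM.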

Compound 4, half-maximal inhibitory concentration: 4.4 nM
The estimate for compound 4 lay 2.7-fold (0.44 log units) above the measured number; the measured number falls inside the stated range.
By their numbers in this assay, from the lowest: compounds 4 and 3 (each within the scatter of the next); then compounds 2 and 1 (each within the scatter of the next).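

In this assay, a ring with a hydrogen-bond acceptor on the oxygen on the aromatic ring stands level with the open chain, a 1.3-fold lower number from compound 3 to compound 4 (0.10 log units; within the scatter), so oxan-4-yl serves here as well as pentan-3-yl. The distance from the other two groups remains, with a 13-fold lower number from compound 2 to compound 4 (1.10 log units; beyond the scatter) and a 16-fold lower number from compound 1 to compound 4 (1.21 log units; beyond the scatter); among these four compounds, the two branched at the carbon bound to that oxygen, compound 3 and compound 4, share the low numbers, and no compound goes against this. No supporting data accompany these numbers to explain the result.

The compounds shown do not separate the effect of the ring from that of its oxygen: cyclohexyl, the all-carbon ring, lies outside the set. As far as these compounds go, the response to a ring amine, as in piperidin-4-yl, also remains open.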